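Dropping the methoxy from compound 3

This account rests on a few compounds, and the source may have more. Where it says the series, first, only, none or still open, it means among the compounds named here.

Measured so far:
- compound 1, `Cc1ccc2nc(C(=O)Nc3c(F)cc(-c4cccc(F)c4)cc3F)c(C)c(O)c2c1`: 56.4%
- compound 2, `CCc1ccc2nc(C(=O)Nc3c(F)cc(-c4cccc(F)c4)cc3F)c(C)c(O)c2c1`: 47.3%
- compound 3, `COc1ccc2nc(C(=O)Nc3ccc(-c4ccccc4)cc3)c(C)c(O)c2c1`: 66.9%

All three were tested in a functional assay on A-375 cells (Homo sapiens) for antiproliferative activity, read by MTT assay, with a stated time of 24 h, tested at 100 ug/mL; on this read-out lower numbers stand for a weaker effect and higher numbers for a stronger effect at the one concentration tested. Compound 3 gives the highest of the three numbers; compound 1 with 56.4% and compound 2 with 47.3% both sit beyond the usual scatter below it. Within the data shown here, the only one-step comparison among the measured compounds is a number 9.1 percentage points lower from compound 1 to compound 2 (within the scatter), which involves methyl in place of hydrogen on a saturated chain carbon bound to an aromatic carbon and leaves the read-out essentially where it was.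

Compound 4, `Cc1c(C(=O)Nc2ccc(-c3ccccc3)cc2)nc2ccccc2c1O`, differs from compound 3 by hydrogen in place of methoxy on an aromatic carbon. Among the measured compounds shown here, no measured step removes a methoxy, so the change has no direct precedent here; the one step that does exist, altering a small substituent on the same carbocyclic part of the shared core, stayed within the scatter. On that thin basis a shift of a number 6.9 percentage points lower from compound 3 to compound 4 (within the scatter) is expected, which is no change beyond the scatter. Compound 4 is therefore estimated to give 60%, between 42% and 76%.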

Compound 4, a percentage reported as inhibition, at one concentration (the size of the read-out at that concentration, not a potency): 52.3%
Beside the measured number, compound 4's estimate is 7.7 percentage points above it; the range from low to high includes it.
By their numbers in this assay, from the lowest: compounds 2, 4 and 1 (each within the scatter of the next); then compound 3.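

In this assay, among these compounds, the change to hydrogen in place of methoxy gives the first step here that clearly exceeds the usual scatter (a number 14.6 percentage points lower from compound 3 to compound 4 (beyond the scatter)). The earlier step on a small substituent (a number 9.1 percentage points lower from compound 1 to compound 2 (within the scatter)) gave no such signal, whereas this pair shows that removing the methoxy from this aromatic carbon of the shared core can move the read-out, though only modestly. Nothing available explains the drop, and this one pair gives the direction of the change without its origin.

From the compounds shown here alone, whether a hydroxyl group, a chlorine atom or a longer chain such as ethoxy on this carbon would keep the higher number of compound 3 remains open. Going by these compounds, it is also open whether the step would keep its size with the fluorine atoms of compound 1 present.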